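The source may report more compounds than this note shows. Statements on the series, on what has been measured and on what is new or still open speak of the compounds shown alone.

Measured compounds in an ADME assay on HepG2 cells (Homo sapiens) for cytotoxicity, read by luminescence, CellTiter-Glo and ATP content, with a stated time of 72 h; a lower number here means that less compound is needed, a higher number that more compound is needed for the effect:

- compound 1, `COc1ccccc1Oc1ccc2c(NCCCNCc3ccco3)ccnc2c1`: 6500 nM
- compound 2, `COc1ccc(Oc2ccc3c(NCCCNCc4cccc(OC)c4O)ccnc3c2)cc1`: 5500 nM
- compound 3, `COc1ccc(F)cc1CNCCCNc1ccnc2cc(Oc3ccc(C(C)(C)C)cc3)ccc12`: 7200 nM

The three measured compounds share the same core and the same three-carbon diamine linker, and differ in the aryl group on the core and in the group on the terminal amine. In this assay compound 1 gives 6500 nM. Compound 1 stands second highest of the three numbers; the nearest is compound 3, whose number is slightly higher, and the furthest is compound 2, whose number is slightly lower, and both of those gaps lie within the scatter. Taken together the three values describe a flat set, with no separation that can be read as an order.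

The unmeasured compound 4, `COc1ccc(-c2ccc3c(NCCCNCc4ccco4)ccnc3c2)cc1`, is reached from compound 1 by 4-methoxyphenyl in place of 2-methoxyphenoxy on an aromatic carbon. Within the data shown here, no pair of measured compounds isolates this change, so there is no measured step to lean on. Given that all three measured values sit so close together despite differing aryl groups and terminal amine substituents, no step beyond the scatter is expected from compound 1 to compound 4 in this assay; the expected step is a 1.1-fold lower number from compound 1 to compound 4 (0.03 log units; within the scatter). For compound 4 the estimate in this assay is 6000 nM, with a range from 2500 nM to 14000 nM.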

Compound 4, half-maximal effective concentration: 6000 nM
Compound 4: the middle estimate sits on the measured number at the digits printed; measured number inside the range.
By their numbers in this assay, from the lowest: compounds 2, 4, 1 and 3 (each within the scatter of the next).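

In this assay the series now has its first comparison that differs in one place: a 1.1-fold lower number from compound 1 to compound 4 (0.03 log units; within the scatter), with 4-methoxyphenyl in place of 2-methoxyphenoxy on an aromatic carbon of the shared core and the three-carbon diamine linker and its terminal amine group unchanged. Among these compounds, the flat reading of the earlier compounds could not be assigned to any single place, whereas this pair shows that this one exchange of aryl groups, at this position, leaves the number within the scatter. The exchange removes the linking oxygen and alters the place of the methoxy group together, so the step covers both and cannot separate them, and nothing available bears on why the number holds.

Open, as far as these compounds go, is how this assay reads at this aromatic carbon with a group of a different kind, such as a carboxylic acid, a morpholine ring or a plain hydrogen, as both groups compared here are methoxy-bearing aromatic rings. Also open, from the compounds shown here alone, is the reading with a longer chain in place of the three-carbon diamine linker, with 4-methoxyphenyl kept on the core.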